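Fluoro to trifluoromethyl: a small step expected

This account rests on a few compounds, and the source may have more. Where it says the series, first, only, none or still open, it means among the compounds named here.

Compound 1 `COc1ccc2nc(C)cc(NCc3cccc(F)c3)c2c1`: 11300 nM
Compound 2 `COc1ccc2nc(C)cc(NCc3ccc(F)c(F)c3)c2c1`: 9100 nM

These values come from a functional assay on MCF-10A cells (Homo sapiens) for antiproliferative activity, with a stated time of 48 h; a lower number here means that less compound is needed, a higher number that more compound is needed for the effect. Going by the values given here, compound 2 cannot be told apart from compound 1, since the only measured step, a 1.2-fold lower number from compound 1 to compound 2 (0.09 log units; within the scatter), is too small to rank them. Compound 3 `COc1ccc2nc(C)cc(NCc3ccc(F)c(C(F)(F)F)c3)c2c1` has trifluoromethyl in place of fluoro on an aromatic carbon, ortho to a fluoro group (trifluoromethyl in place of fluoro on an aromatic carbon). The measured step involves a different swap, so it is only a loose guide, but it offers no reason to expect a large shift in this assay. The expected step is a 1.0-fold lower number from compound 2 to compound 3 (0.00 log units; within the scatter), nothing beyond the scatter. Compound 3 is estimated at 9000 nM, with an expected range of 4000 nM to 20000 nM.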

Compound 3, half-maximal effective concentration: 11300 nM
Compound 3: middle estimate off by 1.3-fold (0.10 log units), on the low side; low and high end bracket the measured number.
By their numbers in this assay, from the lowest: compounds 2, 1 and 3 (each within the scatter of the next).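

Swapping fluoro for trifluoromethyl at this position, ortho to a fluoro group, gives a 1.2-fold higher number from compound 2 to compound 3 (0.09 log units; within the scatter) in this assay, so the assay does not separate these two groups here. The earlier step covered only adding fluoro in place of hydrogen; this one shows that a group with more heavy atoms also leaves the number within the scatter. No available data explain this result.

As far as these compounds go, whether a different kind of group at this position, such as an amine or a carboxylic acid, would move the number beyond the scatter remains open.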